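Chloro to bromo on the six-membered aromatic ring

This account rests on a few compounds, and the source may have more. Where it says the series, first, only, none or still open, it means among the compounds named here.

Measured compounds in an assay on isolated protein for inhibition of Indoleamine 2,3-dioxygenase 1 (Homo sapiens), read by spectrophotometry; a higher number here means a weaker inhibitor, a lower number a stronger inhibitor:
- compound 1, `O/N=C(/Nc1ccccc1)c1ccc2occc2c1`, gives > 30000 nM; this value is a limit of this assay, not a number.
- compound 2, `O/N=C(/Nc1cccc(Cl)c1)c1ccc2occc2c1`, gives 690 nM.

Within the data shown here, compound 2 thus holds the only number in this assay; the other value shown is a limit, (the limit of > 30000 nM in this assay, at which 1 of the 2 values shown sits). Between these two compounds the single measured step is an at least 43-fold lower number from compound 1 to compound 2 (1.63 log units; beyond the scatter), so the introduction of a chloro group at this position moves the readout from a limit into the measured range by a large margin.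

The next compound in the series is compound 3, `O/N=C(/Nc1cccc(Br)c1)c1ccc2occc2c1`. It differs from compound 2 by bromo in place of chloro on an aromatic carbon, the new group sitting meta to a large group as the chloro did. Among the measured compounds shown here, no measured step swaps one of these two groups for the other; the only step available, from compound 1 to compound 2, tells that the position accepts chloro, not how bromo compares to it. On that basis no step beyond the scatter is expected from compound 2 to compound 3: a 1.4-fold lower number from compound 2 to compound 3 (0.14 log units; within the scatter). For compound 3 the estimated value in this assay is 500 nM, with a range from 180 nM to 1500 nM.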

Compound 3, half-maximal inhibitory concentration: 440 nM
Estimate against measurement, compound 3: 1.1-fold (0.06 log units) above, and the stated range covers the measured number.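

In this assay, bromo in place of chloro on the six-membered aromatic ring gives a 1.6-fold lower number from compound 2 to compound 3 (0.20 log units; within the scatter), so the two halogens cannot be told apart here and the position accepts a second halogen as well as the first. Bromo in place of hydrogen gives an at least 68-fold lower number from compound 1 to compound 3 (1.83 log units; beyond the scatter), which stands alongside the earlier chloro step and shows that the large change from hydrogen is not tied to chloro alone. That step is a bound and not a size, because compound 1 gives a limit and not a number: the limit of > 30000 nM in this assay, at which 1 of the 3 values shown sits.

With only hydrogen, chloro and bromo shown at this carbon, it remains open whether a group other than a halogen, such as methoxy, an amine or a carboxylic acid, would keep a value in the range of compound 2 and compound 3. Also open is whether chloro or bromo would hold up on another carbon of this ring, as both groups shown here sit meta to a large group.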